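Thiophen-3-yl in place of 4-methoxyphenyl: working notes

A few compounds are considered here, and "the series" means these few. Any claim that something is new, unique, unknown or untested is made for them only; others in the source may bear on it.

- compound 1 `Nc1ncnn2c([C@@H]3O[C@H](CO)[C@@H](O)[C@H]3O)cc(-c3ccc(F)cc3)c12`: > 100000 nM (a limit, not a number)
- compound 2 `COc1ccc(-c2cc([C@@H]3O[C@H](CO)[C@@H](O)[C@H]3O)n3ncnc(N)c23)cc1`: 62600 nM

Going by the values given here, in a functional assay on Z-138 cells (Homo sapiens) for antiproliferative activity, with a stated time of 72 h (on this read-out lower numbers stand for stronger inhibition and higher numbers for weaker inhibition), compound 2 holds the only actual number. The one other entry is the limit of > 100000 nM in this assay, at which 1 of the 2 values shown sits, and it belongs to compound 1.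

Compound 3 `Nc1ncnn2c([C@@H]3O[C@H](CO)[C@@H](O)[C@H]3O)cc(-c3ccsc3)c12` is next, with thiophen-3-yl in place of 4-methoxyphenyl on an aromatic carbon.

Among the compounds with values here, one measured step bears on this change: an at least 1.5-fold lower number from compound 1 to compound 2 (0.20 log units; that floor lies within the scatter). That step is methoxy in place of fluoro on an aromatic carbon, and its floor lies within the scatter. It is only a loose guide, since compound 3 replaces the whole 4-methoxyphenyl group. On these data alone, no step beyond the scatter is therefore expected, and the direction stays open.

The estimated change is a 1.6-fold lower number from compound 2 to compound 3 (0.19 log units; within the scatter). For compound 3 the expected value is 40000 nM, with an estimated range of 4000 nM to 100000 nM.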

Compound 3, half-maximal inhibitory concentration: 43500 nM
For compound 3 the middle estimate is 1.1-fold (0.04 log units) below the measured one; measured number inside the range.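

In this assay, thiophen-3-yl at this position gives a 1.4-fold lower number from compound 2 to compound 3 (0.16 log units; within the scatter), so a five-membered aromatic ring with 1 hetero atom reads level with the 4-methoxyphenyl group despite having fewer heavy atoms. Set against 4-fluorophenyl, the same group gives an at least 2.2-fold lower number from compound 1 to compound 3 (0.36 log units; beyond the scatter), the first step in the series that lies beyond the scatter. The entry for compound 1 is a limit and not a number, so the true size of that step stays unknown: the limit of > 100000 nM in this assay, at which 1 of the 3 values shown sits.

All three compounds carry an aromatic ring at this position, which leaves open whether a non-aromatic group, such as an amine or a longer alkyl chain, would be accepted there. On these data alone, it is also open how a carboxylic acid on the thiophene ring would read in this assay.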